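The compounds below may be only part of what the source reports. "The series", "measured", "known", "first", "only" and "open" are said of these compounds alone.

Measured in an in vitro ADME assay on microsomes from liver (Homo sapiens) for metabolic stability; a higher number here means faster removal of the compound, a lower number slower removal:

- Compound 1 `Cc1ncc(Cc2nc(-c3nc(C(F)(F)F)n[nH]3)n3ccccc23)cn1`: < 8 mL.min-1.g-1
- Compound 2 `NC(=O)c1n[nH]c(-c2nc(Cc3ccccc3F)c3ccccn23)n1`: < 8 mL.min-1.g-1
- Compound 3 `Cc1ncc(Cn2nc(-c3nc(C(F)(F)F)n[nH]3)c3cccnc32)cn1`: < 7 mL.min-1.g-1

None of these three entries is a number, since each is a limit of the assay. Compound 3 stands at < 7 mL.min-1.g-1, which is a limit. Compound 4 `Fc1ncncc1Cn1nc(-c2nc(C(F)(F)F)n[nH]2)c2cccnc21` has not yet been measured in this assay. It carries 4-fluoropyrimidin-5-yl in place of 2-methylpyrimidin-5-yl on a saturated chain carbon bound to an aromatic nitrogen. Among the measured compounds shown here, no measured pair in this small set shows what such a change does, and no exact starting number is available. The expectation therefore rests only on compound 3 with its limit of < 7 mL.min-1.g-1. The expected change is a number no lower from compound 3 to compound 4 (the limit leaves the size open), which means no step beyond the scatter and no firm direction. A limit is again a likely outcome of the measurement. For compound 4 the estimated value is 7 mL.min-1.g-1, with an expected range of 5 mL.min-1.g-1 to 15 mL.min-1.g-1.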

Compound 4, intrinsic clearance in microsomes: < 11 mL.min-1.g-1
Compound 4 gave a limit, no number; the forecaster's own chance of this, stated with the estimate: 65%; the middle value is on the limit's open side.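

In this assay, among the compounds shown here, compound 4 gives < 11 mL.min-1.g-1 as a limit, and compound 3 also stands at a limit, so no step between the two can be read. The compounds shown leave open how fast any of them is removed, and whether 4-fluoropyrimidin-5-yl in place of 2-methylpyrimidin-5-yl changes that.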